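Phenyl on the sulfonamide nitrogen of compound 3

This account rests on a few compounds, and the source may have more. Where it says the series, first, only, none or still open, it means among the compounds named here.

The series shares one core. In an assay on cells (Hepatocyte) for inhibition of glucokinase regulatory protein (Mus musculus), with stated times of 20 min and 40 min (a higher number here means that more compound is needed for the effect, a lower number that less compound is needed), compound 1 `CC#C[C@H]1CN(S(=O)(=O)c2ccc(N)nc2)CCN1c1ccc(C(O)(COC)C(F)(F)F)cc1` gives 202 nM. Compound 2 `CC#C[C@H]1CN(S(=O)(=O)c2ccc(N)nc2)CCN1c1ccc([S+](C)[O-])cc1` reaches only a limit of this assay, > 12500 nM. Compound 3 `CC#C[C@H]1CN(S(=O)(=O)c2ccc(N)nc2)CCN1c1ccc(S(N)(=O)=O)cc1` gives 37 nM, the lowest number among the measured compounds. The steps leading to it were a 5.5-fold lower number from compound 1 to compound 3 (0.74 log units; beyond the scatter) and an at least 330-fold lower number from compound 2 to compound 3 (2.52 log units; beyond the scatter), the latter resting on (the limit of > 12500 nM in this assay, at which 1 of the 3 values shown sits). Compound 4 `CC#C[C@H]1CN(S(=O)(=O)c2ccc(N)nc2)CCN1c1ccc(S(=O)(=O)Nc2ccccc2)cc1` carries phenyl in place of hydrogen on a sulfonamide nitrogen. Among the measured compounds shown here, no measured step alters the sulfonamide nitrogen itself, so this step has no direct precedent; the sulfamoyl group carried the favourable steps, and whether substitution on its nitrogen keeps them is untested. A modestly higher number is expected for compound 4, 120 nM (30 nM to 500 nM), meaning an expected 3.2-fold higher number from compound 3 to compound 4 (0.51 log units; beyond the scatter).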

Compound 4, half-maximal effective concentration: > 12500 nM
Compound 4: only a limit was reported; the forecaster's own chance of this, stated with the estimate: 5%; middle value at least 100-fold (2.01 log units) away from the limit.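

Phenyl on the sulfonamide nitrogen removes the gain carried by the sulfamoyl group in this assay, with an at least 330-fold higher number from compound 3 to compound 4 (2.52 log units; beyond the scatter). Compound 4 also falls behind compound 1, with an at least 61-fold higher number from compound 1 to compound 4 (1.79 log units; beyond the scatter), while the step from compound 2 cannot be read, as both values are limits. The value of compound 4 is a limit and not a number, so both readable steps give only a minimum size: the limit of > 12500 nM in this assay, at which 2 of the 4 values shown sit.

From the compounds shown here alone, whether the loss belongs to phenyl or to any substituent on this nitrogen stays open; methyl or ethyl here would separate the two. Going by these compounds, the true size of the step also stays open.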